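The source may report more compounds than this note shows. Statements on the series, on what has been measured and on what is new or still open speak of the compounds shown alone.

Of the compounds shown here, two have been measured in an assay on isolated protein for binding affinity to 5-hydroxytryptamine receptor 3A (Homo sapiens); a higher number here means a weaker inhibitor, a lower number a stronger inhibitor. Compound 1, with the structure `CC(=O)N1CCN(CCN2CCC(CNC(=O)c3cccc4[nH]c(C(C)C)nc34)CC2)CC1`, gives 39800 nM in this assay. Compound 2, with the structure `CS(=O)(=O)N1CCN(CC(O)CN2CCC(NC(=O)c3cccc4[nH]cnc34)CC2)CC1`, gives 63100 nM in this assay. Compound 1 thus has the lowest of the two numbers, but the gap to compound 2 lies within the usual scatter of repeated measurements, so the two numbers should be read as alike; both describe weak binding.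

The next compound, compound 3, has the structure `COC(=O)N(C)CC(O)CN1CCC(CNC(=O)c2cccc3[nH]c(C(C)C)nc23)CC1` and has not yet been measured in this assay. It differs from compound 1 in one place: 1-hydroxy-2-((methoxycarbonyl)(methyl)amino)ethyl in place of (4-acetylpiperazin-1-yl)methyl on a saturated chain carbon bound to an amine nitrogen in a ring. The shared core with its isopropyl group is kept, as is the ring amine and the amide linkage.

Among the compounds with values here, no step between measured compounds is known for this kind of change, so the expectation for compound 3 rests on the two weak binders alone. The step from compound 1 to compound 3 is expected to be a 1.1-fold higher number from compound 1 to compound 3 (0.05 log units; within the scatter), that is, no change beyond the scatter, because compound 1 already gives 39800 nM and compound 2, built on a related hydroxy-bearing chain, gives a number in the same range. Compound 3 is therefore expected to show about 45000 nM in this assay, within a range from 12000 nM to 170000 nM.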

Compound 3, inhibition constant: 50100 nM
Compound 3: the middle estimate sits 1.1-fold (0.05 log units) below what was measured; measured number inside the range.
By their numbers in this assay, from the lowest: compounds 1, 3 and 2 (each within the scatter of the next).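

In this assay, putting 1-hydroxy-2-((methoxycarbonyl)(methyl)amino)ethyl in place of (4-acetylpiperazin-1-yl)methyl on a saturated chain carbon bound to an amine nitrogen in a ring gives a 1.3-fold higher number from compound 1 to compound 3 (0.10 log units; within the scatter) and so leaves the two compounds reading as alike. Within the data shown here, this is the first direct comparison at this position, and it shows that a six-membered non-aromatic ring can be exchanged for an open chain carrying a hydrogen-bond donor with no shift beyond the scatter, while binding stays weak. No separate measurement bears on this result.

The exchange alters the ring, the hydroxy group and the methoxycarbonyl end all at once, so it cannot show what any one of these parts does alone, or whether their contributions simply offset each other. A simple primary amine or a carboxylic acid at the end of the chain, or a longer chain, would test whether any group at this position can move the number beyond the scatter.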